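The source may report more compounds than this note shows. Statements on the series, on what has been measured and on what is new or still open speak of the compounds shown alone.

In a functional assay on HepG2 cells (Homo sapiens) for cytotoxicity, read by sulforhodamine B assay, with a stated time of 24 h (on this read-out lower numbers stand for stronger inhibition and higher numbers for weaker inhibition), three compounds sharing one core have been measured. Compound 1 `N#CCC(=O)N/N=C1\C(=O)Nc2ccc(S(=O)(=O)N3CCOCC3)cc21` gives 7530 nM, compound 2 `Cc1ccc(/N=C2\C(=O)Nc3ccc(S(=O)(=O)N4CCOCC4)cc32)cc1` gives 12800 nM and compound 3 `O=C1Nc2ccc(S(=O)(=O)N3CCOCC3)cc2/C1=N/c1ccc(O)cc1` gives 10400 nM, so compound 3 lies within the scatter of both others. Compound 4 `O=C1Nc2ccc(S(=O)(=O)N3CCOCC3)cc2/C1=N/c1cccc(C(F)(F)F)c1` carries 3-(trifluoromethyl)phenyl in place of 4-hydroxyphenyl on a double-bonded nitrogen. The closest evidence is a 1.2-fold lower number from compound 2 to compound 3 (0.09 log units; within the scatter), with hydroxy in place of methyl on an aromatic carbon. Larger swaps on that nitrogen gave a 1.7-fold higher number from compound 1 to compound 2 (0.23 log units; within the scatter) and a 1.4-fold higher number from compound 1 to compound 3 (0.14 log units; within the scatter). None of these steps exceeds the scatter, so no real change is expected in this assay, and the expected move is only a 1.0-fold lower number from compound 3 to compound 4 (0.02 log units; within the scatter). For compound 4 the estimated value is 10000 nM, with an expected range from 4500 nM to 22000 nM.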

Compound 4, half-maximal inhibitory concentration: 14300 nM
Estimate against measurement, compound 4: 1.4-fold (0.16 log units) below, and the stated range covers the measured number.
By their numbers in this assay, from the lowest: compounds 1, 3, 2 and 4 (each within the scatter of the next).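

In this assay, 3-(trifluoromethyl)phenyl has 0 hydrogen-bond donors where 4-hydroxyphenyl has 1, yet the swap gives a 1.4-fold higher number from compound 3 to compound 4 (0.14 log units; within the scatter). Compared with the other two groups on this double-bonded nitrogen, it gives a 1.1-fold higher number from compound 2 to compound 4 (0.05 log units; within the scatter) and a 1.9-fold higher number from compound 1 to compound 4 (0.28 log units; within the scatter), so a hydrogen-bond donor in this group is not needed to stay within the scatter of these compounds. No measurement shown here accounts for these small differences. Still open, on these data alone, is whether an amine or a carboxylic acid on the aromatic ring, or a longer chain on this nitrogen, would move the number beyond the scatter.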